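Adding a hydroxy group to the diphenylmethyl arm

A few compounds are considered here, and "the series" means these few. Any claim that something is new, unique, unknown or untested is made for them only; others in the source may bear on it.

Compound 1 `O=C(O)Cc1sc(C(c2ccccc2)c2ccccc2)nc1-c1ccc(F)cc1` is the starting point. In an in vitro assay on HEK385-7 cells for displacement of a labelled ligand from prostaglandin D2 receptor 2 (Homo sapiens) (a lower number here means a stronger inhibitor, a higher number a weaker inhibitor), compound 1 gives 8.7 nM, the lowest of the two numbers available. Among the measured compounds shown here, its only measured neighbour is compound 2 `O=C(O)Cc1sc(C(c2ccccc2)c2ccccc2)nc1-c1ccc(C(F)(F)F)cc1`, which in this assay gives 1100 nM; that step, a 130-fold higher number from compound 1 to compound 2 (2.10 log units; beyond the scatter), sits on the six-membered ring attached to the shared core. Compound 3 `O=C(O)Cc1sc(C(c2ccccc2)c2ccc(O)cc2)nc1-c1ccc(F)cc1` carries a different change: hydroxy in place of hydrogen on an aromatic carbon, on one of the two phenyl rings of the diphenylmethyl arm. For the measured compounds named here, no measured step touches that arm, so the only evidence is indirect: the one known change elsewhere on compound 1 was large, showing the assay does respond strongly to single substituent changes. A small added group on an unexplored ring is expected to move the number only modestly, as a step of a 1.7-fold higher number from compound 1 to compound 3 (0.24 log units; within the scatter). Compound 3 is therefore estimated at 15 nM, within 4 nM to 60 nM.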

Compound 3, half-maximal inhibitory concentration: 3.4 nM
The estimate for compound 3 lay 4.4-fold (0.64 log units) above the measured number; measured number below the stated range.
By their numbers in this assay, from the lowest: compound 3; then compound 1; then compound 2.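

Hydroxy in place of hydrogen, on one phenyl ring of the diphenylmethyl arm, gives a 2.6-fold lower number from compound 1 to compound 3 (0.41 log units; beyond the scatter) in this assay. Among the compounds shown here, this is the first measured change on that arm, and it shows that the arm accepts an added group here without a loss of potency. The step is modest and runs the opposite way to a 130-fold higher number from compound 1 to compound 2 (2.10 log units; beyond the scatter) on the other ring, although these are two different groups at two different places, so no general rule follows. No measurement shown here explains why the number falls.

As far as these compounds go, it remains open whether the lower number is specific to hydroxy or would also appear with methoxy, an amine or a carboxylic acid at the same place. Also open, from the compounds shown here alone, is what a second hydroxy group on the other phenyl ring of the arm would do.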